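This account rests on a few compounds, and the source may have more. Where it says the series, first, only, none or still open, it means among the compounds named here.

Measured so far:
compound 1, `Cc1cc(Nc2ccccn2)n2nc(C)c(-c3ccccc3)c2n1`: < 5000 nM
compound 2, `Cc1cc(NCc2ccccn2)n2nc(C)c(Nc3ccccc3)c2n1`: 7800 nM
compound 3, `Cc1cc(NCc2ccccn2)n2nc(C)cc2n1`: > 200000 nM

In a physicochemical assay for solubility, read by HPLC, using the shake flask method, measured as kinetic solubility, with a stated time of 2 h, at pH 7.4 (a higher number here means a more soluble compound, a lower number a less soluble compound), compound 1 gives < 5000 nM, which is a limit of the assay and not a number (the limit of < 5000 nM in this assay, at which 1 of the 3 values shown sits). Compound 2, which carries an anilino group and a methylene-linked pyridine, gives 7800 nM in this assay. Compound 3 gives > 200000 nM, again a limit of the assay and not a number (the limit of > 200000 nM in this assay, at which 1 of the 3 values shown sits).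

Among the compounds with values here, only one step between measured compounds differs in a single place: an at least 25-fold higher number from compound 2 to compound 3 (1.40 log units; beyond the scatter). Within the data shown here, compound 1 and compound 2 differ in two places at once, so their two values show only that compound 1 sits at a limit while compound 2 gives a number.

Compound 4, `Cc1cc(NCc2ccc(F)cn2)n2nc(C)c(-c3ccccc3)c2n1`, differs from compound 1 as follows: (5-fluoropyridin-2-yl)methyl in place of pyridin-2-yl on a nitrogen on an aromatic ring. The measured step concerns the anilino group, which neither compound 1 nor compound 4 carries, so it does not bear on this change. Among the measured compounds shown here, no measured pair speaks to a methylene linker or to a fluorine on the pyridine.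

For the measured compounds named here, with no relevant step to lean on, the expectation for compound 4 is a change no larger than the scatter, a number no lower from compound 1 to compound 4 (the limit leaves the size open). Compound 4 is therefore estimated at 5000 nM in this assay, within a range from 1500 nM to 15000 nM, with a fair chance that only a limit is reported.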

Compound 4, solubility: < 5000 nM
Compound 4 was reported as a limit; the forecaster's own chance of this, stated with the estimate: 40%; the middle value sits exactly at the limit.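

In this assay compound 4 gives < 5000 nM as a limit of the assay and not a number. Compound 1 stands at the same limit, so no step can be read between compound 1 and compound 4: the limit of < 5000 nM in this assay, at which 2 of the 4 values shown sit. The compounds shown leave open what (5-fluoropyridin-2-yl)methyl in place of pyridin-2-yl does to solubility beneath that limit.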